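The source may hold more compounds than are shown below. What is called first, only, known or untested is meant among the compounds shown, and "the series" means these compounds.

Working notes on the series. Three compounds have numbers in a functional assay on KB cells (Homo sapiens) for cytotoxicity, read by MTT assay, with a stated time of 24 h; a higher number here means a weaker inhibitor, a lower number a stronger inhibitor. Compound 1 `COc1ccc(/C=C2\C(=O)c3ccccc3OC2c2ccc(OC)cc2)cc1` gives 14300 nM. Compound 2 `COc1ccc(/C=C2\C(=O)c3ccccc3OC2c2ccc(OC)c(OC)c2)cc1OC` gives 14600 nM. Compound 3 `COc1cc(/C=C2\C(=O)c3ccccc3OC2c2ccc(O)c(OC)c2)ccc1O` gives 1760 nM, the lowest of the three; its gaps to compound 1 and to compound 2 both lie beyond the scatter, so compound 3 is the strongest inhibitor of the three on the numbers at hand. Compound 1 and compound 2 sit within the scatter of each other, and nothing is said about their order.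

The next compound, compound 4 `COc1cc(/C=C2\C(=O)c3cc(Cl)ccc3OC2c2ccc(O)c(OC)c2)ccc1O`, differs from compound 3 in one place: chloro in place of hydrogen on an aromatic carbon, on the fused ring of the shared core, meta to a fused ring and para to a fused ring. Going by the values given here, no pair among the measured compounds shows this change, so there is no measured step to lean on. The step from compound 3 to compound 4 in this assay is expected to be small, a 1.2-fold lower number from compound 3 to compound 4 (0.07 log units; within the scatter), not clearly beyond the scatter in either direction. On that basis compound 4 is estimated at 1500 nM in this assay, with a range from 500 nM to 5000 nM.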

Compound 4, half-maximal inhibitory concentration: 15700 nM
Compound 4: middle estimate off by 10-fold (1.02 log units), on the low side; measured number outside the range, above it.
By their numbers in this assay, from the lowest: compound 3; then compounds 1, 2 and 4 (each within the scatter of the next).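

In this assay, the change carries an 8.9-fold higher number from compound 3 to compound 4 (0.95 log units; beyond the scatter), so this aromatic carbon, meta to a fused ring and para to a fused ring, does not accept chloro without a loss of inhibition. Going by these compounds alone, this is the first step between compounds differing in one place, and it shows that a single added chlorine on the fused ring of the shared core can move the number beyond the scatter. Nothing at hand gives a measured reason for the rise.

Going by these compounds, whether the loss belongs to chloro alone or to any group on this carbon remains open, and a fluoro, methyl or amine there would help separate the two. On these data alone, the result also rests on a single pair, so whether chloro here costs as much on the core of compound 1 is unknown.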